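The source may report more compounds than this note shows. Statements on the series, on what has been measured and on what is new or still open speak of the compounds shown alone.

In a functional assay on Fem-X cells (Homo sapiens) for cytotoxicity, read by MTT assay, with a stated time of 72 h (on this read-out lower numbers stand for stronger inhibition and higher numbers for weaker inhibition), compound 1 (`CC(C)(C)C1=CC(=O)C=C(NCC(=O)O)C1=O`) gives 34300 nM and compound 2 (`CC1=CCC[C@H]2[C@](C)(CC3=CC(=O)C(N4CCC[C@H]4C(=O)O)=CC3=O)[C@@H](C)CC[C@]12C`) gives 39600 nM while compound 3 (`CC1=CCC[C@H]2[C@](C)(CC3=CC(=O)C=CC3=O)[C@@H](C)CC[C@]12C`) gives 40300 nM so compound 3 stands level with both, all three within the scatter. Compound 4 (`CC1=CCC[C@H]2[C@](C)(CC3=CC(=O)C=C(NCC(=O)O)C3=O)[C@@H](C)CC[C@]12C`) carries (carboxymethyl)amino in place of hydrogen on a double-bonded ring carbon on the core of compound 3. Going by the values given here, the one measured step at such a carbon is a 1.0-fold higher number from compound 2 to compound 3 (0.01 log units; within the scatter) and it stays within the scatter. Compound 1 carries the same group on a different core and gives 34300 nM in the same range. The expected step is a 1.3-fold lower number from compound 3 to compound 4 (0.13 log units; within the scatter) in this assay and nothing beyond the scatter is expected. Compound 4 is estimated at 30000 nM with an expected range from 12000 nM to 70000 nM in this assay for now.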

Compound 4, half-maximal inhibitory concentration: 17800 nM
Compound 4: the middle estimate sits 1.7-fold (0.23 log units) above what was measured; low and high end bracket the measured number.
By their numbers in this assay, from the lowest: compounds 4, 1, 2 and 3 (each within the scatter of the next, the first and the last beyond it).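

In this assay (carboxymethyl)amino in place of hydrogen on a double-bonded ring carbon, two ring bonds from the ring atom that bears a large group, gives a 2.3-fold lower number from compound 3 to compound 4 (0.35 log units; beyond the scatter) as a modest step, the only one so far beyond the scatter. The other measured change at such a carbon, a 1.0-fold higher number from compound 2 to compound 3 (0.01 log units; within the scatter) and within the scatter, involves a different group. Nothing at hand gives a cause for the new step.

Open, going by these compounds, is whether a plain amine at this place, without the carboxylic acid, gives a similar step on this core. On these data alone, a longer chain ending in a carboxylic acid is equally open.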